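The source may hold more compounds than are shown below. What is called first, only, known or untested is meant among the compounds shown, and "the series" means these compounds.

Working notes on the series: in an ADME assay on L02 cells (Homo sapiens) for cytotoxicity, read by MTT assay, with a stated time of 24 h (on this read-out lower numbers stand for stronger inhibition and higher numbers for weaker inhibition), compound 1 (`O=C1/C(=C/c2cccnc2)CN(S(=O)(=O)c2ccccc2)C/C1=C\c1ccccc1F`) gives 15300 nM and compound 3 (`O=C1/C(=C/c2cccnc2)CN(S(=O)(=O)c2ccccc2)C/C1=C\c1ccccc1C(F)(F)F`) gives 12500 nM. For the measured compounds named here, these are the only two exact numbers so far, and compound 3 stands within the scatter of compound 1, the step being a 1.2-fold lower number from compound 1 to compound 3 (0.09 log units; within the scatter). Compound 2 (`N#Cc1ccc(S(=O)(=O)N2C/C(=C\c3ccncc3)C(=O)/C(=C/c3ccccc3F)C2)cc1`) reads > 20000 nM, which is a limit.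

Compound 4 (`O=C1/C(=C/c2cccnc2)CN(S(=O)(=O)c2ccc(Cl)cc2)C/C1=C\c1ccccc1C(F)(F)F`) carries chloro in place of hydrogen on an aromatic carbon of compound 3, para to a large group, so that phenylsulfonyl becomes (4-chlorophenyl)sulfonyl: chloro in place of hydrogen on an aromatic carbon. Going by the values given here, no measured step tests this place. The only one at hand is a 1.2-fold lower number from compound 1 to compound 3 (0.09 log units; within the scatter), trifluoromethyl in place of fluoro on an aromatic carbon elsewhere in the molecule, and it bears only indirectly. On that basis, no step beyond the scatter is expected in this assay, with a slight lean towards a lower number.

The expected step is a 1.1-fold lower number from compound 3 to compound 4 (0.06 log units; within the scatter). Compound 4 is estimated at 11000 nM, with an expected range from 6000 nM to 20000 nM.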

Compound 4, half-maximal inhibitory concentration: 11900 nM
Compound 4: the middle estimate sits 1.1-fold (0.03 log units) below what was measured, within the range that was stated.
By their numbers in this assay, from the lowest: compounds 4, 3 and 1 (each within the scatter of the next). At a limit, above all of these: compound 2.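

For the compounds shown here, the step from hydrogen to chloro is the only reading at this place on the phenylsulfonyl part: in this assay, the change gives a 1.1-fold lower number from compound 3 to compound 4 (0.02 log units; within the scatter). Taken with a 1.2-fold lower number from compound 1 to compound 3 (0.09 log units; within the scatter), this means that single changes at two different places on the shared core have each stayed within the scatter, so neither place yet separates these compounds in this cytotoxicity read-out. Steps to compound 2 cannot be read, since its value is a limit and not a number: the limit of > 20000 nM in this assay, at which 1 of the 4 values shown sits.

As far as these compounds go, it remains open whether a more different group in the same place, para to a large group, such as an amine or a carboxylic acid in place of chloro, would give a step beyond the scatter. From the compounds shown here alone, it also remains open whether any single change at this place would bring a compound to that limit.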